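Chloro for methyl on the pendant phenyl: a second look

This account rests on a few compounds, and the source may have more. Where it says the series, first, only, none or still open, it means among the compounds named here.

Measured so far:
compound 1 `CCOC(=O)c1c(-c2c(Cl)c3ccccc3oc2=O)nn(-c2cccc(C)c2)c1C(=O)OCC` — 32000 nM
compound 2 `CCOC(=O)c1c(-c2c(Cl)c3ccccc3oc2=O)nn(-c2cccc(Cl)c2)c1C(=O)OCC` — 24000 nM
compound 3 `CCOC(=O)c1c(-c2cc3ccc(OCC=C(C)C)cc3oc2=O)nn(-c2cccc(C)c2)c1C(=O)OCC` — 125000 nM

The series was tested in a functional assay on DU-145 cells (Homo sapiens) for cytotoxicity, read by MTT assay, with a stated time of 48 h; on this read-out lower numbers stand for stronger inhibition and higher numbers for weaker inhibition. Compounds 1 and 2 share one core, and compound 3 carries another; the difference between the two cores is not broken down here. In this assay compound 1 gives 32000 nM and compound 2 gives 24000 nM. The change between them is chloro in place of methyl on an aromatic carbon, and the step it made is a 1.3-fold lower number from compound 1 to compound 2 (0.12 log units; within the scatter).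

Compound 3 gives 125000 nM, the highest number of the three; its gap to compound 1 and to compound 2 lies beyond the scatter.

Compound 4 `CCOC(=O)c1c(-c2cc3ccc(OCC=C(C)C)cc3oc2=O)nn(-c2cccc(Cl)c2)c1C(=O)OCC` has not yet been measured. It differs from compound 3 by chloro in place of methyl on an aromatic carbon, the same change as between compound 1 and compound 2, made on the same place of the pendant ring. Since the earlier step of this change, a 1.3-fold lower number from compound 1 to compound 2 (0.12 log units; within the scatter), stayed within the scatter, the step from compound 3 to compound 4 is expected to be of about that size, a 1.3-fold lower number from compound 3 to compound 4 (0.10 log units; within the scatter). On that basis compound 4 is estimated at 100000 nM in this assay, with an expected range from 50000 nM to 200000 nM.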

Compound 4, half-maximal inhibitory concentration: 139000 nM
Estimate against measurement, compound 4: 1.4-fold (0.14 log units) below, and the stated range covers the measured number.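

In this assay, within the data shown here, the exchange of 3-methylphenyl for 3-chlorophenyl on the second core gives a 1.1-fold higher number from compound 3 to compound 4 (0.05 log units; within the scatter), so on this core too the change leaves no step that can be told from the scatter. Set beside the earlier step, the new one does not differ from it, and the change carries across the two cores without a detectable difference in its size: the same change on two cores in this assay, a 1.3-fold lower number (0.12 log units; within the scatter) from compound 1 to compound 2 and a 1.1-fold higher number (0.05 log units; within the scatter) from compound 3 to compound 4, 1.5-fold (0.17 log units) apart, within the scatter of two such steps This shows only that chloro and methyl on this aromatic carbon cannot be told apart in this cell read-out on either core; it does not show that the change has no effect in general, since two small steps say nothing about a third core or about any other read-out, and they give no reason for the result.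

What the compounds shown leave open is whether any group on this aromatic carbon would produce a step beyond the scatter, for instance an amine, a carboxylic acid or a longer chain in place of the methyl or chloro. As far as these compounds go, it is equally open whether such a group would behave alike on both cores, as chloro and methyl do here.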